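The compounds below may be only part of what the source reports. "The series", "measured", "known", "first", "only" and "open" are said of these compounds alone.

In a functional assay on SMMC-7721 cells (Homo sapiens) for cytotoxicity, read by MTT assay, with a stated time of 24 h (on this read-out lower numbers stand for stronger inhibition and higher numbers for weaker inhibition), compound 1 `O=C1/C(=C/c2cccnc2)CNC/C1=C\c1ccccc1C(F)(F)F` gives 5100 nM. Compound 2 `O=C1/C(=C/c2cccnc2)CN(S(=O)(=O)c2ccc(Cl)cc2)C/C1=C\c1ccccc1C(F)(F)F`, which has a (4-chlorophenyl)sulfonyl group in place of hydrogen on an amine nitrogen in a ring, gives 4880 nM. These two numbers lie within the usual scatter of repeated measurements, so compound 2 stands level with compound 1 and neither can be ranked above the other.

Compound 3 `N#Cc1ccc(S(=O)(=O)N2C/C(=C\c3cccnc3)C(=O)/C(=C/c3ccccc3C(F)(F)F)C2)cc1` keeps the sulfonyl group and alters only its aromatic ring: cyano in place of chloro on an aromatic carbon. In words, this is cyano in place of chloro on an aromatic carbon, para to a large group. Among the measured compounds shown here, only one measured step bears on this change. Adding the entire (4-chlorophenyl)sulfonyl group gave a 1.0-fold lower number from compound 1 to compound 2 (0.02 log units; within the scatter), which is within the scatter. For the measured compounds named here, no measured compound here carries a cyano group, so this single step is thin evidence, but the swap touches only one substituent of that added group. No shift beyond the scatter is therefore expected, and the estimated change is a 1.0-fold lower number from compound 2 to compound 3 (0.01 log units; within the scatter). For compound 3 the estimated value is 4800 nM, with an expected range from 2400 nM to 9500 nM.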

Compound 3, half-maximal inhibitory concentration: 9650 nM
Beside the measured number, compound 3's estimate is 2.0-fold (0.30 log units) below it, outside the stated range (above it).
By their numbers in this assay, from the lowest: compounds 2, 1 and 3 (each within the scatter of the next).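

In this assay, cyano in place of chloro on an aromatic carbon, para to a large group, gives a 2.0-fold higher number from compound 2 to compound 3 (0.30 log units; within the scatter) and so sits at the very edge of the usual scatter without passing it, which means this position has not yet produced a readable difference between two substituents. Placing the whole (4-cyanophenyl)sulfonyl group on the ring amine nitrogen in place of hydrogen gives a 1.9-fold higher number from compound 1 to compound 3 (0.28 log units; within the scatter) and also stays within the scatter, so the nitrogen bearing hydrogen and the two sulfonyl compounds cannot be ranked against one another, and the earlier finding of no readable effect from adding a sulfonyl group now holds for two different aromatic substituents. No measurement of any other property accompanies these numbers, so the data offer no explanation for the values.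

The compounds shown leave open whether an amine or a carboxylic acid on that same aromatic carbon would move the number beyond the scatter. They also leave open whether a simple acetyl group on the ring nitrogen, with no sulfonyl and no aromatic ring, would read any differently in this assay from the groups tested so far.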